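The source may report more compounds than this note shows. Statements on the series, on what has been measured and on what is new or still open speak of the compounds shown alone.

In an ADME assay on the whole organism (serum) with Homo sapiens as the target (a higher number here means that the compound lasts longer, a lower number that the compound disappears faster), three analogues built on one shared core have already been measured. Compound 1 `Cc1cn(C2CC(N=[N+]=[N-])C(COC(=O)NCCCC(=O)OC(C)(C)C)O2)c(=O)[nH]c1=O` gives a value that is a limit of the assay, > 48 h. Compound 2 `Cc1cn(C2CC(N=[N+]=[N-])C(COC(=O)OCCCC(=O)OC(C)(C)C)O2)c(=O)[nH]c1=O` gives 0.267 h in this assay, and compound 3 `Cc1cn(C2CC(N=[N+]=[N-])C(COC(=O)OCCCCO)O2)c(=O)[nH]c1=O` gives 0.5 h. Among the values that are numbers, compound 3 stands highest, with compound 2 nearest to it, but the step of a 1.9-fold higher number from compound 2 to compound 3 (0.27 log units; within the scatter) lies within the scatter, so the two cannot be set in order. Compound 4 `Cc1cn(C2CC(N=[N+]=[N-])C(COC(=O)CCCC(=O)O)O2)c(=O)[nH]c1=O` is the one still to be measured. It differs from compound 3 by 3-carboxypropyl in place of 4-hydroxybutoxy on a carbonyl carbon. Among the compounds with values here, no measured step touches this carbonyl carbon directly. Within the data shown here, the only step whose size is known, a 1.9-fold higher number from compound 2 to compound 3 (0.27 log units; within the scatter), changed a chain end and stayed within the scatter, and the value of compound 1 sits at the limit of > 48 h in this assay, at which 1 of the 3 values shown sits. Nothing shown therefore points to a step beyond the scatter in this assay for compound 4, and the step that this estimate means is a 1.4-fold higher number from compound 3 to compound 4 (0.15 log units; within the scatter). Compound 4 is expected to give 0.7 h in this assay, with an estimated range from 0.25 h to 3 h.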

Compound 4, half-life: 30 h
The estimate for compound 4 lay 43-fold (1.63 log units) below the measured number; the measured number lies above the stated range.
By their numbers in this assay, from the lowest: compounds 2 and 3 (each within the scatter of the next); then compound 4. At a limit, above all of these: compound 1.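

In this assay the exchange of 4-hydroxybutoxy for 3-carboxypropyl on this carbonyl carbon gives a 60-fold higher number from compound 3 to compound 4 (1.78 log units; beyond the scatter) and is the only step shown that lies beyond the scatter. Within the data shown here, the earlier step of a 1.9-fold higher number from compound 2 to compound 3 (0.27 log units; within the scatter) at the chain end stayed within the scatter, so only this exchange shows that the number can move by a large step, and the two groups exchanged here have the same count of heavy atoms, so that count does not separate compound 3 from compound 4. Compound 1 remains at a limit of the assay and not at a number: (the limit of > 48 h in this assay, at which 1 of the 4 values shown sits).

The exchange alters the atom bound to this carbonyl carbon and the end of the chain together, so the compounds shown do not tell which of the two carries the step, and a 4-hydroxybutyl or a 3-carboxypropoxy group at this place would separate them. They also do not tell how a longer chain or an amine at the chain end would fare in this assay and they give no cause for the step.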